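Bromo-indazole amines: five-membered ring swap at the chain carbon

The source may hold more compounds than are shown below. What is called first, only, known or untested is meant among the compounds shown, and "the series" means these compounds.

Measured so far in an assay for inhibition of Indoleamine 2,3-dioxygenase 1 (Homo sapiens), with a stated time of 1 h, tested at 10 uM; a lower number here means less inhibition, a higher number more inhibition at the concentration tested (going by the name of the read-out):
compound 1 `Nc1ccc(CNc2cc(Br)cc3[nH]ncc23)cc1`, 3%
compound 2 `Brc1cc(NCc2ccco2)c2cn[nH]c2c1`, 29%
compound 3 `Brc1cc(NCc2cccs2)c2cn[nH]c2c1`, 54%

Compound 3 stands highest of the three numbers in this assay; compound 2 is nearest and compound 1 furthest, both beyond the scatter. Within the data shown here, the only single-point step measured is a number 25 percentage points higher from compound 2 to compound 3 (beyond the scatter), which shows that the five-membered ring on the saturated chain carbon bound to a nitrogen on the aromatic ring moves the read-out by a modest amount.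

Compound 4 `Brc1cc(NCc2cnc[nH]2)c2cn[nH]c2c1` is not yet measured. Its change from compound 3 is 1H-imidazol-5-yl in place of thiophen-2-yl on a saturated chain carbon bound to a nitrogen on an aromatic ring. Among the measured compounds shown here, no measured step pairs thiophen-2-yl against 1H-imidazol-5-yl, so the step from compound 2 to compound 3 is the only guide, and it runs from the ring with one hetero atom toward the sulfur ring, not toward a ring with two hetero atoms. For the measured compounds named here, the only other compound carrying a hydrogen-bond donor on the group at that position is compound 1, which gives 3% in this assay, while compound 3 gives 54%.

For compound 4 a drop is therefore expected, a number 29 percentage points lower from compound 3 to compound 4 (beyond the scatter), with wide uncertainty. The estimate for compound 4 in this assay is 25%, expected between 5% and 50%.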

Compound 4, a percentage reported as inhibition, at one concentration (the size of the read-out at that concentration, not a potency): 16%
Estimate against measurement, compound 4: 9 percentage points above; measured number inside the range.
By their numbers in this assay, from the lowest: compound 1; then compound 4; then compound 2; then compound 3.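

In this assay, the steps of a number 38 percentage points lower from compound 3 to compound 4 (beyond the scatter) and a number 13 percentage points lower from compound 2 to compound 4 (beyond the scatter) place 1H-imidazol-5-yl below both rings with 1 hetero atom at this position, on a saturated chain carbon bound to a nitrogen on an aromatic ring. Thiophen-2-yl and 1H-imidazol-5-yl each have 5 heavy atoms, so the read-out here can move well beyond the scatter with no change in that count. No supporting evidence bears on why the number falls with this ring swap.

The change to 1H-imidazol-5-yl alters the hetero atoms and the hydrogen-bond donor count together, and nothing shown separates the two. A thiazol-2-yl ring, a 1-methylimidazol-5-yl ring or a longer chain carrying thiophen-2-yl would each probe this position further.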